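The source may report more compounds than this note shows. Statements on the series, on what has been measured and on what is new or still open speak of the compounds shown alone.

Among the measured compounds shown here, in a functional assay on HepG2 cells (Homo sapiens) for antiproliferative activity, read by XTT assay, with a stated time of 72 h (on this read-out lower numbers stand for stronger inhibition and higher numbers for weaker inhibition), the two compounds measured so far both stop at the edge of what the assay can report. Compound 1, with the structure `CN(C)c1ncnc2c1c(-c1ccsc1)cn2[C@@H]1O[C@H](CO)[C@@H](O)[C@H]1O`, gives > 20000 nM in this assay, a limit rather than a number. Compound 2, with the structure `CSc1ncnc2c1c(-c1cccs1)cn2[C@@H]1O[C@H](CO)[C@@H](O)[C@H]1O`, likewise gives > 20000 nM in this assay, again a limit and not a measured value. Both values therefore sit at the limit of > 20000 nM in this assay, at which 2 of the 2 values shown sit, so neither compound shows measurable inhibition of growth here.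

Compound 3, with the structure `CN(C)c1ncnc2c1c(-c1cccs1)cn2[C@@H]1O[C@H](CO)[C@@H](O)[C@H]1O`, has not yet been tested. It differs from compound 2 by dimethylamino in place of methylsulfanyl on an aromatic carbon. For the measured compounds named here, no step between measured compounds is available to size this change. Since compound 2 gives > 20000 nM and the same dimethylamino group already appears in compound 1 at > 20000 nM, the step from compound 2 to compound 3 is expected to be a step that the limit leaves unreadable from compound 2 to compound 3, in all likelihood no movement beyond the scatter. Compound 3 is therefore expected to give 30000 nM, with a likely range from 8000 nM to 120000 nM, most probably again reported only as a limit.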

Compound 3, half-maximal inhibitory concentration: > 20000 nM
Compound 3: no number, only a limit; the forecaster's own chance of this, stated with the estimate: 85%; the middle value is on the limit's open side.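

Compound 3 stops at the same limit as compound 1 and compound 2, so neither of its two single changes, dimethylamino for methylsulfanyl or thiophen-2-yl for thiophen-3-yl, can be read as a step: the limit of > 20000 nM in this assay, at which 3 of the 3 values shown sit.

The compounds shown leave open whether either change alters growth inhibition at all.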